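Swapping a basic side chain for methoxy on a triazole series

The source may report more compounds than this note shows. Statements on the series, on what has been measured and on what is new or still open speak of the compounds shown alone.

Compound 1 `Cc1ccc(-c2cn(-c3ccc(CN4CCCC4)cc3)nn2)cc1Nc1nccc(-c2cccnc2)n1`: 1570 nM
Compound 2 `Cc1ccc(-n2cc(-c3ccc(CN4CCN(C)CC4)c(C(F)(F)F)c3)nn2)cc1Nc1nccc(-c2cccnc2)n1`: 20 nM

In a functional assay on HL-60 cells (Homo sapiens) for inhibition, read by MTT assay, with a stated time of 72 h (a higher number here means a weaker inhibitor, a lower number a stronger inhibitor), compound 2 gives the lower of the two numbers; compound 1 sits far above it, well beyond the scatter. Compound 3 `COc1ccc(-c2cn(-c3ccc(C)c(Nc4nccc(-c5cccnc5)n4)c3)nn2)cc1C(F)(F)F` has not been measured. It differs from compound 2 in one place: methoxy in place of (4-methylpiperazin-1-yl)methyl on an aromatic carbon. Going by the values given here, no measured pair shows this particular change, so nothing observed sets its size. Compound 3 is expected to be weaker than compound 2 in this assay, by a step of a 7.5-fold higher number from compound 2 to compound 3 (0.88 log units; beyond the scatter), clearly beyond the scatter. Compound 3 is estimated at 150 nM, within a range from 40 nM to 600 nM.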

Compound 3, half-maximal inhibitory concentration: 21200 nM
Compound 3: middle estimate off by 140-fold (2.15 log units), on the low side; measured number outside the range, above it.
By their numbers in this assay, from the lowest: compound 2; then compound 1; then compound 3.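

In this assay, replacing (4-methylpiperazin-1-yl)methyl with methoxy on the aromatic carbon ortho to a trifluoromethyl group gives a 1100-fold higher number from compound 2 to compound 3 (3.03 log units; beyond the scatter) and so shows that this position is far from indifferent to what it carries. In this pair, the number of compound 2 depends heavily on the (4-methylpiperazin-1-yl)methyl group. No evidence at hand accounts for the size of this step.

As far as these compounds go, it remains open whether the loss follows the ring or the amine nitrogen of the departing group. A dimethylaminomethyl or morpholin-4-ylmethyl group on this carbon would help separate the two.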